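The source may hold more compounds than are shown below. What is called first, only, known or untested is meant among the compounds shown, and "the series" means these compounds.

The measured compounds:

compound 1, `O=C1CC(c2ccccc2OCc2cccc(F)c2)Oc2ccccc21`, 92.7%
compound 2, `CC(C)=CCOc1ccccc1C1CC(=O)c2ccccc2O1`, 40.3%
compound 3, `CC(C)c1ccc(COc2ccccc2C2CC(=O)c3ccccc3O2)cc1`, 91.7%

In a functional assay on J774.A1 cells (Mus musculus) for inhibition, read by immunoassay, with a stated time of 12 h, tested at 30 uM (a lower number here means less inhibition, a higher number more inhibition at the concentration tested (going by the name of the read-out)), compound 1 stands highest of the three numbers. Compound 3 sits nearest, with a number 1 percentage points lower from compound 1 to compound 3 (within the scatter), which is within the scatter. Compound 2 sits furthest, with a number 52.4 percentage points lower from compound 1 to compound 2 (beyond the scatter), a large fall.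

Compound 4, `COCOc1ccccc1C1CC(=O)c2ccccc2O1`, differs from compound 1 in one place: methoxy in place of 3-fluorophenyl on a saturated chain carbon bound to an oxygen on an aromatic ring. Among the compounds with values here, two measured steps bear on this. The step from compound 1 to compound 3 swaps one aromatic group for another and leaves the number unchanged. The step from compound 1 to compound 2 removes the aromatic ring in favour of an open chain and costs a great deal. The change to compound 4 likewise removes the aromatic ring, and what enters is smaller still. A large downward step in this assay is therefore expected for compound 4, because a number 52.4 percentage points lower from compound 1 to compound 2 (beyond the scatter) shows what the loss of the ring did. The expected step is a number 54.7 percentage points lower from compound 1 to compound 4 (beyond the scatter). Compound 4 is estimated at 38%, within 12% to 64%.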

Compound 4, a percentage reported as inhibition, at one concentration (the size of the read-out at that concentration, not a potency): 33.3%
The estimate for compound 4 lay 4.7 percentage points above the measured number; the range from low to high includes it.
By their numbers in this assay, from the lowest: compounds 4 and 2 (each within the scatter of the next); then compounds 3 and 1 (each within the scatter of the next).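

In this assay, methoxy in place of 3-fluorophenyl gives (a number 59.4 percentage points lower from compound 1 to compound 4 (beyond the scatter)) and methoxy in place of 4-isopropylphenyl gives (a number 58.4 percentage points lower from compound 3 to compound 4 (beyond the scatter)), so a second group without a ring now falls far short of both aromatic groups at this position. Methoxy in place of 2-methylprop-1-en-1-yl gives (a number 7 percentage points lower from compound 2 to compound 4 (within the scatter)), which puts these two groups without a ring level with each other, although the computed heavy-atom count shows that methoxy is small. Nothing available explains why the groups without a ring fall so far.

The compounds shown leave open whether a saturated ring such as cyclohexyl would hold the number seen with the aromatic groups. They also leave open what an amine or a carboxylic acid at this position would give.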